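Anilide in place of aryl ketone on the thioether chain

The source may report more compounds than this note shows. Statements on the series, on what has been measured and on what is new or still open speak of the compounds shown alone.

Compound 3 `COc1cc(-c2nnc(SCC(=O)c3ccc(F)c(F)c3)n2N)cc(OC)c1OC` sits at a limit of a functional assay on PC-3 cells (Homo sapiens) for antiproliferative activity, read by MTT assay, with a stated time of 48 h; a lower number here means a stronger inhibitor, a higher number a weaker inhibitor: compound 3 gives > 100000 nM, which is a limit and not a number. Compound 1 `COc1cc(-c2nnc(SCC(=O)c3ccccc3)n2N)cc(OC)c1OC` gives > 100000 nM, also a limit. Compound 2 `COc1cc(-c2nnc(SCC(=O)c3ccc(F)cc3)n2N)cc(OC)c1OC` gives > 100000 nM, again a limit. The steps a step that the two limits leave unreadable from compound 1 to compound 2, a step that the two limits leave unreadable from compound 1 to compound 3 and a step that the two limits leave unreadable from compound 2 to compound 3 are therefore unreadable, as the limit of > 100000 nM in this assay, at which 3 of the 3 values shown sit, records. Compound 4 `COc1cc(-c2nnc(SCC(=O)Nc3ccc(C)cc3)n2N)cc(OC)c1OC` carries (4-methylphenyl)amino in place of 3,4-difluorophenyl on a carbonyl carbon. Among the compounds with values here, no measured step bears on this change; the three compounds show only that the shared core with an aryl ketone chain stays at the limit. Compound 4 is expected at 100000 nM, within 20000 nM to 300000 nM. The step of a number no higher from compound 3 to compound 4 (the limit leaves the size open) is thus estimated as no change beyond the scatter, most likely another limit.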

Compound 4, half-maximal inhibitory concentration: 43100 nM
Compound 4: middle estimate off by 2.3-fold (0.37 log units), on the high side, and the stated range covers the measured number.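

In this assay, placing (4-methylphenyl)amino on the carbonyl carbon gives the first readable activity at this position: an at least 2.3-fold lower number from compound 3 to compound 4 (0.36 log units; beyond the scatter), an at least 2.3-fold lower number from compound 2 to compound 4 (0.36 log units; beyond the scatter) and an at least 2.3-fold lower number from compound 1 to compound 4 (0.36 log units; beyond the scatter). The exact size of each step stays open, as the ketone partners are limits and only bound it: the limit of > 100000 nM in this assay, at which 3 of the 4 values shown sit.

What the compounds shown leave open is whether the change rests on the amide hydrogen or on the 4-methylphenyl ring. Phenylamino, 3,4-difluorophenylamino or cyclohexylamino on the same carbonyl carbon would separate these.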